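This account rests on a few compounds, and the source may have more. Where it says the series, first, only, none or still open, it means among the compounds named here.

Series notes. Among the compounds with values here, the shared core is that of compound 2 `CN(C)CCNc1nc(-c2ccc(NC(=O)Nc3ccc(Cl)cc3)cc2)nc2ccsc12`, which in a functional assay on HT-29 cells (Homo sapiens) for cytotoxicity, read by MTT assay, with a stated time of 72 h (a lower number here means a stronger inhibitor, a higher number a weaker inhibitor), gives 95 nM and holds the lowest of the three numbers measured so far, each other compound separated from it by a step beyond the scatter. Compound 1 `CN(C)CCNc1nc(-c2ccc(NC(=O)Nc3ccccc3F)cc2)nc2ccsc12` gives 510 nM in the same assay, and compound 3 `CN(C)CCNc1nc(-c2ccc(NC(=O)Nc3ccc(Cl)cc3Cl)cc2)nc2ccsc12` gives 1320 nM. Every step among these three sits on the aryl urea: a 5.4-fold lower number from compound 1 to compound 2 (0.73 log units; beyond the scatter), a 2.6-fold higher number from compound 1 to compound 3 (0.41 log units; beyond the scatter) and a 14-fold higher number from compound 2 to compound 3 (1.14 log units; beyond the scatter). Compound 4 `CCN(CC)CCCNc1nc(-c2ccc(NC(=O)Nc3ccc(Cl)cc3)cc2)nc2ccsc12` keeps the urea of compound 2 unchanged and differs only in the amine side chain: (diethylamino)methyl in place of dimethylamino on a saturated chain carbon, two bonds along the chain from a nitrogen on an aromatic ring. Within the data shown here, none of the measured steps bears on that part of the molecule; all three change the aryl urea and leave the side chain untouched, so the data give no direct guide to the size or direction of this change. What is carried forward is the urea that gave compound 2 its standing. With nothing pointing either way, the expected step is a 1.1-fold higher number from compound 2 to compound 4 (0.02 log units; within the scatter), that is, none beyond the scatter. The estimate for compound 4 in this assay is therefore 100 nM, with a range from 35 nM to 300 nM, pending the measurement.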

Compound 4, half-maximal inhibitory concentration: 58 nM
For compound 4 the middle estimate is 1.7-fold (0.24 log units) above the measured one, and the stated range covers the measured number.
By their numbers in this assay, from the lowest: compounds 4 and 2 (each within the scatter of the next); then compound 1; then compound 3.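

In this assay, the replacement of 2-(dimethylamino)ethyl by 3-(diethylamino)propyl on the amine side chain gives a 1.6-fold lower number from compound 2 to compound 4 (0.21 log units; within the scatter), so with the 4-chlorophenyl urea held fixed, this position accepts the larger group without a step beyond the scatter. Within the data shown here, this is the first measured change away from the aryl urea, and it contrasts with a 14-fold higher number from compound 2 to compound 3 (1.14 log units; beyond the scatter), a step on the urea that lies beyond the scatter, although a single pair cannot define the tolerance of the side chain. Nothing available explains the result or links it to any property of either side chain.

Chain length and the substituents on the terminal nitrogen change together in this pair, so their separate contributions remain unresolved; 3-(dimethylamino)propyl and 2-(diethylamino)ethyl side chains would separate them. Also open, on these data alone, are how side chains ending in a ring amine, such as morpholine or piperidine, would read here and whether the same side chain change gives a similar step when paired with the 2,4-dichlorophenyl or 2-fluorophenyl urea.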